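A few compounds are considered here, and "the series" means these few. Any claim that something is new, unique, unknown or untested is made for them only; others in the source may bear on it.

Compound 1 `COC(=O)CCNC(=O)[C@@H]1O[P@@](=O)(OCOC(=O)c2ccnn2C)OCC1(C)C` and compound 3 `COC(=O)CCNC(=O)[C@@H]1O[P@](=O)(OCOC(=O)c2ccnn2C)OCC1(C)C` share one skeleton and differ only in configuration as drawn. In an ADME assay on blood (Homo sapiens) for pharmacokinetics (a lower number here means that the compound disappears faster, a higher number that the compound lasts longer), compound 1 reaches a limit of the assay, > 1 h. Compound 2 `CC(C)(C)C(=O)OCO[P@@]1(=O)OCC(C)(C)[C@H](C(=O)NCCC(=O)O)O1` also sits at a limit in this assay, giving > 1 h. Compound 3 lies at the opposite limit in this assay, < 0.16 h. The step of an at least 6.2-fold lower number from compound 1 to compound 3 (0.79 log units; beyond the scatter) is therefore at least modest, and compound 3 stands at the short end of the three values shown. Compound 4 `COC(=O)CCNC(=O)[C@@H]1O[P@](=O)(OCOC(=O)c2ccns2)OCC1(C)C` has not been measured; it differs from compound 3 by 1,2-thiazol-5-yl in place of 1-methyl-1H-pyrazol-5-yl on a carbonyl carbon. For the measured compounds named here, no measured step touches that carbonyl substituent, and compound 4 is expected to stay close to compound 3, with an expected step that the limit leaves unreadable from compound 3 to compound 4. Compound 4 is estimated at 0.12 h, within 0.05 h to 0.3 h.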

Compound 4, half-life: < 0.16 h
Compound 4: a limit, no number; the forecaster's own chance of this, stated with the estimate: 70%; the middle value does not contradict the limit.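

In this assay compound 3 gives < 0.16 h, which is a limit. For the compounds shown here, compound 4 gives < 0.16 h, also a limit, so no step between compound 3 and compound 4 can be read. The compounds shown leave open how 1,2-thiazol-5-yl and 1-methyl-1H-pyrazol-5-yl on a carbonyl carbon compare in this assay.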